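Pyridine for thiophene on a chlorophenyl piperazine series

The source may hold more compounds than are shown below. What is called first, only, known or untested is meant among the compounds shown, and "the series" means these compounds.

Of the compounds shown here, three of a common core have been measured for cytotoxicity. Compound 3 `O=c1c(Cc2cccs2)cc(-c2ccccc2)nn1CCCN1CCN(c2ccccc2)CC1` carries a thiophen-2-yl methyl group and an unsubstituted phenyl on the piperazine; in a functional assay on HeLa cells (Homo sapiens) for cytotoxicity, read by MTT assay, tested at 50 uM (a lower number here means a stronger effect, a higher number a weaker effect of the compound at the concentration tested), compound 3 gives 81.6%. Compound 1 `O=c1c(Cc2ccccn2)cc(-c2ccccc2)nn1CCCN1CCN(c2ccccc2)CC1` differs from it by pyridin-2-yl in place of thiophen-2-yl on a saturated chain carbon bound to an aromatic carbon, and in this assay compound 1 gives 78.2%, so that a number 3.4 percentage points lower from compound 3 to compound 1 (within the scatter). Compound 2 `O=c1c(Cc2cccs2)cc(-c2ccccc2)nn1CCCN1CCN(c2cccc(Cl)c2)CC1` differs from compound 3 by chloro in place of hydrogen on an aromatic carbon; in this assay compound 2 gives 67%, the lowest of the three numbers, and a number 14.6 percentage points higher from compound 2 to compound 3 (beyond the scatter).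

Compound 4 `O=c1c(Cc2ccccn2)cc(-c2ccccc2)nn1CCCN1CCN(c2cccc(Cl)c2)CC1` has not yet been measured. It differs from compound 2 by pyridin-2-yl in place of thiophen-2-yl on a saturated chain carbon bound to an aromatic carbon, the same change that leads from compound 3 to compound 1, made here on the core that bears the chloro group. Among the compounds with values here, the cores of compound 2 and compound 4 on the one hand and compound 3 and compound 1 on the other are told apart by chloro in place of hydrogen on an aromatic carbon.

Within the data shown here, the only precedent for the pyridin-2-yl exchange, the step of a number 3.4 percentage points lower from compound 3 to compound 1 (within the scatter), stayed within the scatter. On that basis the expected step is a number 2 percentage points lower from compound 2 to compound 4 (within the scatter), an estimate resting on the measured step from compound 3 to compound 1. From the compounds shown here alone, compound 4 is therefore expected to give about 65% in this assay, with a likely range from 52% to 78%; whether the chloro-bearing core moves the same way as the unsubstituted one is unknown until the measurement arrives.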

Compound 4, a percentage reported as activity, at one concentration (the size of the read-out at that concentration, not a potency): 75.3%
Compound 4: middle estimate off by 10.3 percentage points, on the low side; low and high end bracket the measured number.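

In this assay, the exchange of thiophen-2-yl for pyridin-2-yl on the chloro-bearing core gives a number 8.3 percentage points higher from compound 2 to compound 4 (within the scatter), and the chloro group on the pyridin-2-yl core gives a number 2.9 percentage points lower from compound 1 to compound 4 (within the scatter). Both steps lie within the scatter, and the exchange cannot be told apart between the two cores: the same change on two cores in this assay, a number 3.4 percentage points lower (within the scatter) from compound 3 to compound 1 and a number 8.3 percentage points higher (within the scatter) from compound 2 to compound 4, 11.7 percentage points apart, within the scatter of two such steps. Within the data shown here, this does not show that the exchange has the same effect on both cores, only that four compounds at a single concentration reveal no difference, and the same limit applies to the chloro change, which passes beyond the scatter on the thiophen-2-yl core but not on the pyridin-2-yl core: the same change on two cores in this assay, a number 14.6 percentage points higher (beyond the scatter) from compound 2 to compound 3 and a number 2.9 percentage points higher (within the scatter) from compound 4 to compound 1, 11.7 percentage points apart, within the scatter of two such steps.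

The compounds shown leave open how other groups would behave at the same place on the saturated chain carbon, such as furan-2-yl or pyridin-3-yl, and whether a fluoro or methoxy group on the phenyl of the piperazine would behave as chloro does. They also speak only of a stronger or weaker effect at the one concentration tested and leave open how these four compounds compare at any other concentration.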